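This account rests on a few compounds, and the source may have more. Where it says the series, first, only, none or still open, it means among the compounds named here.

Within the data shown here, compound 2 `N=C(NCCCc1c[nH]cn1)NCCC(c1ccc(Br)cc1)c1ccccn1` stands highest of the two numbers measured so far in a functional assay on cardiac atrium for agonist activity at histamine H2 receptor (Cavia porcellus); on this read-out lower numbers stand for lower potency and higher numbers for higher potency (the scale is a negative logarithm): compound 2 gives 7.48, while compound 1 `N=C(NCCCc1c[nH]cn1)NCCCC(c1ccc(F)cc1)c1ccccn1` gives 6.87 in this assay, a gap beyond the usual scatter. Compound 3 `N=C(NCCCc1c[nH]cn1)NCCC(c1cc(F)cc(F)c1)c1ccccn1` differs from compound 2 by 3,5-difluorophenyl in place of 4-bromophenyl on a saturated chain carbon bound to an aromatic carbon and a saturated chain carbon. Among the measured compounds shown here, no single-change step comparable to this one has been measured, so the expectation for compound 3 rests on compound 2 alone. A small downward step from compound 2 to compound 3, a number 0.38 log units lower from compound 2 to compound 3 (beyond the scatter), is expected in this assay. Compound 3 is estimated at 7.1, within a range of 6.6 to 7.6.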

Compound 3, negative logarithm of the half-maximal effective concentration: 8.05
The estimate for compound 3 lay 0.95 log units below the measured number; measured number outside the range, above it.
By their numbers in this assay, from the lowest: compound 1; then compound 2; then compound 3.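

In this assay, the saturated chain carbon bound to an aromatic carbon and a saturated chain carbon accepts 3,5-difluorophenyl in place of 4-bromophenyl, with a number 0.57 log units higher from compound 2 to compound 3 (beyond the scatter). The number at this position therefore responds to the substituents on the phenyl ring, and bromine is not required for the higher values seen so far. Nothing available bears on what lies behind this rise. As far as these compounds go, whether the rise follows the two fluorines or the loss of bromine stays open. Also open, from the compounds shown here alone, is how 3,5-dichlorophenyl at this place would compare.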